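Replacing the benzylamine arm of compound 1: expectation for compound 3

The source may hold more compounds than are shown below. What is called first, only, known or untested is meant among the compounds shown, and "the series" means these compounds.

Measured in a functional assay on HCT-116 cells (Homo sapiens) for inhibition, read by MTT assay, with a stated time of 72 h; on this read-out higher numbers stand for weaker inhibition and lower numbers for stronger inhibition:
- compound 1, `COc1cc(Oc2cccc(Nc3ccccc3)c2)cc(OC)c1CNCc1ccccc1`, gives 4070 nM
- compound 2, `COc1cc(Oc2cccc(Nc3ccccc3)c2)cc(OC)c1CNCCNC(C)=O`, gives 18200 nM
- compound 3, `CCN1CCN(Cc2c(OC)cc(Oc3cccc(Nc4ccccc4)c3)cc2OC)CC1`, not yet measured

Compound 1 holds the lowest of the two numbers in this assay, with compound 2 the nearest neighbour. Going by the values given here, the only step available, a 4.5-fold higher number from compound 1 to compound 2 (0.65 log units; beyond the scatter), changes the group on the saturated chain carbon bound to the amine nitrogen.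

Compound 3 arises from compound 1 by a different change: 4-ethylpiperazin-1-yl in place of benzylamino on a saturated chain carbon bound to an aromatic carbon. The step from compound 1 to compound 2 bears on it only loosely, since both alterations sit on the same arm of the shared core, but the piperazine change removes the benzylamine entirely rather than swapping its terminal group. That one step was modest and went toward a higher number. Among the compounds with values here, no measured compound carries a cyclic amine on this arm, so direction is uncertain; a step of roughly the same modest size, toward a higher number, is expected in this assay, estimated as a 1.6-fold higher number from compound 1 to compound 3 (0.20 log units; within the scatter). Compound 3 is therefore expected at about 6500 nM, within 2000 nM to 20000 nM.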

Compound 3, half-maximal inhibitory concentration: > 20000 nM
Compound 3 was reported as a limit; the forecaster's own chance of this, stated with the estimate: 10%; middle value at least 3.0-fold (0.48 log units) away from the limit.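

In this assay, 4-ethylpiperazin-1-yl in place of benzylamino on a saturated chain carbon bound to an aromatic carbon gives an at least 4.9-fold higher number from compound 1 to compound 3 (0.69 log units; beyond the scatter), so a second replacement of the benzylamino group, here one with no aromatic ring and no hydrogen-bond donor, also moves away from compound 1. Against the (2-acetamidoethyl)amino group, the reading is an at least 1.0-fold higher number from compound 2 to compound 3 (0.04 log units; that floor lies within the scatter), which does not put compound 2 and compound 3 in any firm order, while compound 1 keeps the lowest number of the three by steps beyond the scatter. The entry for compound 3 is a limit and not a number: the limit of > 20000 nM in this assay, at which 1 of the 3 values shown sits.

As far as these compounds go, compound 2 and compound 3 both lose the phenyl ring of the benzylamino group, so it remains open whether a group that keeps this ring, such as phenethylamino or N-methylbenzylamino, would hold a number close to that of compound 1. Also open, from the compounds shown here alone, is whether the drop follows from the cyclic amine itself or from the ethyl group on it, a question that piperidin-1-yl or morpholin-4-yl on the same carbon would address.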